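Methylsulfanyl in place of ethynyl on the shared core

The source may report more compounds than this note shows. Statements on the series, on what has been measured and on what is new or still open speak of the compounds shown alone.

Measured in an ADME assay on the whole organism (Rattus norvegicus) for pharmacokinetics, read by HPLC, at a dose of 3 mg/kg by the oral route; on this read-out lower numbers stand for lower exposure and higher numbers for higher exposure at the dose given:
compound 1 `N#Cc1cc(C(=O)N2CS(=O)(=O)c3ccccc32)cc(Cl)c1O`: 3870 nM
compound 2 `C#Cc1cc(C(=O)N2CS(=O)(=O)c3ccccc32)cc(C#N)c1O`: 4670 nM

Going by the values given here, compound 2, at 4670 nM, lies within the scatter of compound 1, the only other measured compound. Compound 3 `CSc1cc(C(=O)N2CS(=O)(=O)c3ccccc32)cc(C#N)c1O` carries methylsulfanyl in place of ethynyl on an aromatic carbon. Among the compounds with values here, the one measured step bearing on this place is a 1.2-fold higher number from compound 1 to compound 2 (0.08 log units; within the scatter), and it involves chloro and ethynyl, not methylsulfanyl. It offers only weak guidance, and no step beyond the scatter is expected in this assay. The expected step is a 1.5-fold lower number from compound 2 to compound 3 (0.16 log units; within the scatter). Compound 3 is estimated at 3200 nM, with an expected range of 1100 nM to 7500 nM.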

Compound 3, maximal plasma concentration: 3000 nM
Estimate against measurement, compound 3: 1.1-fold (0.03 log units) above; measured number inside the range.
By their numbers in this assay, from the lowest: compounds 3, 1 and 2 (each within the scatter of the next).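

In this assay, methylsulfanyl on this aromatic carbon, ortho to a hydroxy group, is a third group that stays within the scatter of the other two, with a 1.6-fold lower number from compound 2 to compound 3 (0.19 log units; within the scatter) and a 1.3-fold lower number from compound 1 to compound 3 (0.11 log units; within the scatter) as its steps. The position has thus taken chloro, ethynyl and methylsulfanyl, the last bringing sulfur and a hydrogen-bond acceptor, with no step beyond the scatter. Nothing measured here explains this flat result.

On these data alone, it remains open whether an amine, a carboxylic acid or a longer chain at this place would give a step beyond the scatter. How any of these compounds behaves by another route or at another dose also remains open.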